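The compounds below may be only part of what the source reports. "The series", "measured", "known", "first", "only" and "open" are said of these compounds alone.

Measured so far in a functional assay on PC-3 cells (Homo sapiens) for antiproliferative activity, read by MTT assay, with a stated time of 48 h; on this read-out higher numbers stand for weaker inhibition of growth and lower numbers for stronger inhibition of growth:

- compound 1 `Cc1ccc(-c2cnc(N(Cc3ccc(C(=O)NO)cc3)CC(C)C)s2)cc1` with 9340 nM
- compound 2 `CCN(Cc1ccc(C(=O)NO)cc1)c1ncc(-c2ccc(C)cc2)s1` with 10300 nM

The numbers of compound 2 and compound 1 lie within the scatter of each other, so neither outranks the other. Compound 3 `CCCCCCCCN(Cc1ccc(C(=O)NO)cc1)c1ncc(-c2ccc(C)cc2)s1` differs from compound 2 by one change (hexyl in place of hydrogen on a saturated chain carbon, two bonds along the chain from a nitrogen on an aromatic ring) , with hexyl in place of hydrogen on a saturated chain carbon, two bonds along the chain from a nitrogen on an aromatic ring. The same difference reads ethyl to octyl. Among the measured compounds shown here, only one measured step bears on this, a 1.1-fold higher number from compound 1 to compound 2 (0.04 log units; within the scatter), also a change on a saturated chain carbon, and it stayed within the scatter. Neither measured compound carries a chain as long as octyl, so that step is only a weak guide. The expected result is a 1.6-fold lower number from compound 2 to compound 3 (0.20 log units; within the scatter), leaning towards a lower number but with no clear shift beyond the scatter. In this assay the estimated value for compound 3 is 6500 nM, with an expected range of 2000 nM to 16000 nM.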

Compound 3, concentration for 50% growth inhibition: 13300 nM
Compound 3: middle estimate off by 2.0-fold (0.31 log units), on the low side; measured number inside the range.
By their numbers in this assay, from the lowest: compounds 1, 2 and 3 (each within the scatter of the next).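

In this assay, adding hexyl at this place, two bonds along the chain from the nitrogen on the aromatic ring, gives a 1.3-fold higher number from compound 2 to compound 3 (0.11 log units; within the scatter). Replacing isopropyl with heptyl, one bond nearer that nitrogen, gives a 1.4-fold higher number from compound 1 to compound 3 (0.15 log units; within the scatter), so even the octyl chain, much longer than the chains on the earlier compounds, cannot be told apart from them on this read-out, and chain size alone has shown no effect here beyond the scatter. No measured evidence is available to explain this result. As far as these compounds go, what remains open is whether a chain ending in an amine or a carboxylic acid, or a phenyl ring at this place, would shift the number beyond the scatter.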